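The source may hold more compounds than are shown below. What is called first, only, known or untested is meant among the compounds shown, and "the series" means these compounds.

In an ADME assay on THP-1 cells (Homo sapiens) for cytotoxicity, read by MTT assay, with a stated time of 72 h (on this read-out higher numbers stand for lower toxicity in this test and lower numbers for higher toxicity in this test), two closely related compounds have already been compared. Compound 1, with the structure `O[C@@H]1Cc2cc(Cl)ccc2N[C@H](c2ccc(Cl)cc2)C1`, gives 49200 nM. Compound 2, with the structure `O[C@@H]1Cc2cc(F)ccc2N[C@H](c2ccc(Cl)cc2)C1`, gives 100000 nM. The two differ only by the change (fluoro in place of chloro on an aromatic carbon), and that change produced the step of a 2.0-fold higher number from compound 1 to compound 2 (0.31 log units; beyond the scatter). In this assay a higher number means the cells tolerated more of the compound, so the move from chloro to fluoro went with somewhat lower toxicity here.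

Compound 3 has the structure `O[C@@H]1Cc2ccccc2N[C@H](c2ccccc2Cl)C1`. For compound 3 the assay reports only a limit, > 300000 nM, not a number. How the core of compound 3 differs from the core of compound 1 is not broken down here.

Compound 4, with the structure `O[C@@H]1Cc2ccccc2N[C@H](c2ccccc2F)C1`, has not yet been measured. It stands to compound 3 as compound 2 stands to compound 1: the change is fluoro in place of chloro on an aromatic carbon. This is the same kind of change as the earlier one, but not the same. The place differs: in compound 1 the swapped halogen sits on a six-membered aromatic ring of carbon only that is part of a fused or bridged system of two rings, meta to a fused ring and para to a fused ring, whereas in compound 3 it sits on a six-membered aromatic ring of carbon only, ortho to a large group.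

Given that compound 3 already sits at the limit of > 300000 nM in this assay, at which 1 of the 3 values shown sits, and that the earlier step was a 2.0-fold higher number from compound 1 to compound 2 (0.31 log units; beyond the scatter), the expected step for compound 4 is a step that the limit leaves unreadable from compound 3 to compound 4. Compound 4 is therefore expected to give about 400000 nM in this assay, most plausibly between 150000 nM and 1000000 nM, and it is quite likely that the assay will again report only a limit.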

Compound 4, half-maximal cytotoxic concentration: > 300000 nM
Compound 4: no number, only a limit; the forecaster's own chance of this, stated with the estimate: 80%; the middle value lies beyond the limit too.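

In this assay compound 4 gives > 300000 nM, which is a limit and not a number. Compound 3 gives > 300000 nM, also a limit, so no step can be read between compound 3 and compound 4. The compounds shown leave open whether fluoro in place of chloro changes the read-out at all on this pair, or by how much, as it did between compound 1 and compound 2.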